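The source may report more compounds than this note shows. Statements on the series, on what has been measured and on what is new or still open speak of the compounds shown alone.

Compound 1 `COc1ccc(S(=O)(=O)N2CCc3cccc(NS(=O)(=O)c4ccc([N+](=O)[O-])cc4)c32)cc1` and compound 2 `COc1ccc(S(=O)(=O)N2CCc3cccc(NCc4ccccc4)c32)cc1` are the two compounds with values in hand. In a functional assay on KB cells (Homo sapiens) for cytotoxicity (on this read-out lower numbers stand for stronger inhibition and higher numbers for weaker inhibition), compound 1 gives 1100 nM. For compound 2 this assay reports only a limit, > 10000 nM, so compound 2 is the compound that stands at the limit of > 10000 nM in this assay, at which 1 of the 2 values shown sits, and no number is known for it. Compound 3 `COc1ccc(S(=O)(=O)N2CCc3cccc(NC(=O)Oc4ccccc4)c32)cc1` has not yet been measured in this assay. It differs from compound 2 in a single place: phenoxycarbonyl in place of benzyl on a nitrogen on an aromatic ring. Because compound 2 sits at the limit (the limit of > 10000 nM in this assay, at which 1 of the 2 values shown sits), the size of the step to compound 3 cannot be anchored to a measured number on that side. The expectation is that compound 3 returns into the measurable range, so that an at least 2.5-fold lower number from compound 2 to compound 3 (0.39 log units; beyond the scatter) is estimated as a step towards stronger inhibition, though it may turn out small or the result may again be a limit. Compound 3 is therefore estimated at 4000 nM in this assay, with a range from 800 nM to 20000 nM, and with a real chance that only a limit is reported.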

Compound 3, half-maximal inhibitory concentration: > 10000 nM
Compound 3: no number, only a limit (the forecaster's own chance of this, stated with the estimate: 40%); middle value at least 2.5-fold (0.39 log units) away from the limit.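

In this assay compound 3 gives > 10000 nM as a limit and not a number. Within the data shown here, compound 2 also stands at a limit, so no step from compound 2 to compound 3 can be read. The compounds shown leave open how strongly either one inhibits, and whether phenoxycarbonyl in place of benzyl changes the result in this assay at all.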